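Weighing a (piperidin-1-yl)carbonyl in place of ethyl

The compounds below may be only part of what the source reports. "The series", "measured", "known", "first", "only" and "open" are said of these compounds alone.

Measured compounds:
compound 1, `CCCN1CCC(CCCn2c(COc3ccc(Cl)cc3)nc3c(C)cccc32)CC1`, 29 nM
compound 2, `Cc1cccc2c1nc(COc1ccc(Cl)cc1)n2CCCC1CCN(Cc2ccccc2)CC1`, 109 nM
compound 3, `Cc1cccc2c1nc(COc1ccc(Cl)cc1)n2CCCC1CCN(CCCc2ccccc2)CC1`, 57 nM

These three share one core and differ only in the group carried on the saturated chain carbon bound to the amine nitrogen in the ring. In an assay on AV12 cells for binding affinity to Neuropeptide Y receptor type 1 (Homo sapiens) (on this read-out higher numbers stand for weaker inhibition and lower numbers for stronger inhibition), compound 1 gives the lowest of the three numbers; compound 3 lies within the scatter of it, a 2.0-fold higher number from compound 1 to compound 3 (0.29 log units; within the scatter), while compound 2 sits further off, a 3.8-fold higher number from compound 1 to compound 2 (0.58 log units; beyond the scatter). Between compound 2 and compound 3 the step is a 1.9-fold lower number from compound 2 to compound 3 (0.28 log units; within the scatter).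

Compound 4, `Cc1cccc2c1nc(COc1ccc(Cl)cc1)n2CCCC1CCN(CC(=O)N2CCCCC2)CC1`, has not yet been measured in this assay. Relative to compound 1 it carries (piperidin-1-yl)carbonyl in place of ethyl on a saturated chain carbon bound to an amine nitrogen in a ring. Within the data shown here, the step from compound 1 to compound 2 is the closest precedent, since it too alters the group on the saturated chain carbon bound to the amine nitrogen in the ring, and it raised the number. The step from compound 1 to compound 3, with the change placed three bonds along the chain, stayed within the scatter. The entering group differs in kind from the phenyl groups tried so far, so the precedent is indirect. Compound 4 is therefore expected to give a modestly higher number, a 4.1-fold higher number from compound 1 to compound 4 (0.62 log units; beyond the scatter). The estimate for compound 4 is 120 nM, within a range of 35 nM to 450 nM.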

Compound 4, inhibition constant: 136 nM
Estimate against measurement, compound 4: 1.1-fold (0.05 log units) below; low and high end bracket the measured number.
By their numbers in this assay, from the lowest: compounds 1, 3, 2 and 4 (each within the scatter of the next, the first and the last beyond it).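

In this assay, (piperidin-1-yl)carbonyl in place of ethyl gives a 4.7-fold higher number from compound 1 to compound 4 (0.67 log units; beyond the scatter), so a group with no aromatic ring, carrying a carbonyl and a six-membered non-aromatic ring, also raises the number from that of compound 1, in the same direction as the phenyl of compound 2. Set against the aromatic groups, the picture is split: the exchange for phenyl stays within the scatter, a 1.2-fold higher number from compound 2 to compound 4 (0.10 log units; within the scatter), while the exchange for phenethyl lies beyond it, a 2.4-fold higher number from compound 3 to compound 4 (0.38 log units; beyond the scatter), so among these compounds an aromatic ring on this carbon is not needed for a number in this range. No measurement is available that would explain these shifts.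

The compounds shown leave open whether the carbonyl or the piperidine ring accounts for the rise, as the two enter together in compound 4. A (dimethylamino)carbonyl would keep the carbonyl without the ring, a plain pentyl chain would carry neither, and a (piperidin-1-yl)methyl would keep the ring without the carbonyl, so each would bear on that question.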